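Side-chain carboxy to carbamoyl: expectation for compound 4

The compounds below may be only part of what the source reports. "The series", "measured", "known", "first", "only" and "open" are said of these compounds alone.

Measured so far in an assay on isolated protein for binding affinity to E-selectin (Homo sapiens); a lower number here means a stronger inhibitor, a higher number a weaker inhibitor:
compound 1, `O=C(O)CC[C@H](NC(=O)CC1OC(CO)C(O)C(O)C1O)C(=O)O`: 3000000 nM
compound 2, `O=C(O)CC[C@@H](NC(=O)CC1OC(CO)C(O)C(O)C1O)C(=O)O`: 7000000 nM
compound 3, `NCCCC[C@@H](NC(=O)CC1OC(CO)C(O)C(O)C1O)C(=O)O`: 7000000 nM

Compound 2 stands level with compound 3, the two together giving the highest numbers of the three; compound 1 gives the lowest, a 2.3-fold higher number from compound 1 to compound 2 (0.37 log units; beyond the scatter). The only thing bearing on that step is the fact that one of compounds 1 and 2 is drawn with a defined configuration and the other without, at the place where they differ. The other measured step is no change at the digits printed from compound 2 to compound 3 (within the scatter).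

Compound 4, `NC(=O)CC[C@@H](NC(=O)CC1OC(CO)C(O)C(O)C1O)C(=O)O`, differs from compound 2 in one place: amino in place of hydroxy on a carbonyl carbon. Among the measured compounds shown here, of the measured steps, only the one that exchanges the carboxy group is relevant, and that step, no change at the digits printed from compound 2 to compound 3 (within the scatter), stayed within the scatter even though it brought in 2-aminoethyl. The stereo step does not touch this group. The change here is smaller still, a carboxy becoming a carbamoyl, so no step beyond the scatter is expected in this assay; the estimate means no change at the digits printed from compound 2 to compound 4 (within the scatter). Compound 4 is expected to give 7000000 nM, with a range from 3000000 nM to 16000000 nM.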

Compound 4, half-maximal inhibitory concentration: > 10000000 nM
Compound 4 ended at the assay's limit; the forecaster's own chance of this, stated with the estimate: 30%; at least 1.4-fold (0.15 log units) between middle value and limit.
By their numbers in this assay, from the lowest: compound 1; then compounds 2 and 3 (each within the scatter of the next). At a limit, above all of these: compound 4.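

In this assay compound 4 sits at a limit of the assay and gives no number: the limit of > 10000000 nM in this assay, at which 1 of the 4 values shown sits.

Carboxy to carbamoyl on this chain gives an at least 1.4-fold higher number from compound 2 to compound 4 (0.15 log units; that floor lies within the scatter), and carbamoyl in place of 2-aminoethyl gives an at least 1.4-fold higher number from compound 3 to compound 4 (0.15 log units; that floor lies within the scatter). Both are floors only, so neither step is shown to lie beyond the scatter, yet carbamoyl is the first group at this position to leave the range in which the assay prints a number.

As far as these compounds go, how far compound 4 lies past its limit stays open, so the true size of both steps is unknown. Also open, from the compounds shown here alone, is how a methyl ester or a longer chain ending in a carboxylic acid would read here, and whether carbamoyl would behave alike with the configuration drawn in compound 1.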